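A few compounds are considered here, and "the series" means these few. Any claim that something is new, unique, unknown or untested is made for them only; others in the source may bear on it.

Measured compounds:
compound 1 `COc1ccc(-c2cc(/C=C/C(=O)c3ccc(N)cc3)[nH]n2)cc1`: 94%
compound 2 `COc1cc(-c2cc(/C=C/C(=O)c3ccc(N)cc3)[nH]n2)cc(OC)c1OC`: 92%

In a functional assay on SR cells (Homo sapiens) for cytotoxicity, read by sulforhodamine B assay, with a stated time of 48 h, tested at 0.01 uM (on this read-out higher numbers stand for a weaker effect at the one concentration tested and lower numbers for a stronger effect), compound 1 gives 94% and compound 2 gives 92%. Compound 2 stands alongside compound 1; the gap between the two numbers lies within the scatter, so neither can be set apart from the other, and both show only a slight effect at the one concentration tested. Compound 3 `COc1cc(-c2cc(/C=C/C(=O)c3ccc(Cl)c(Cl)c3)[nH]n2)cc(OC)c1OC` differs from compound 2 by 3,4-dichlorophenyl in place of 4-aminophenyl on a carbonyl carbon. Going by the values given here, no step between measured compounds is available to gauge this change, and the single pair in hand shows no movement beyond the scatter. The step of no change at the digits printed from compound 2 to compound 3 (within the scatter) is therefore expected to be small, in either direction, if any. Compound 3 is estimated at 92%, with a range from 78% to 104%.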

Compound 3, a percentage reported as activity, at one concentration (the size of the read-out at that concentration, not a potency): 104%
Compound 3: the middle estimate sits 12 percentage points below what was measured; the range from low to high includes it.
By their numbers in this assay, from the lowest: compounds 2, 1 and 3 (each within the scatter of the next, the first and the last beyond it).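

On the carbonyl carbon, 3,4-dichlorophenyl in place of 4-aminophenyl gives a step of a number 12 percentage points higher from compound 2 to compound 3 (beyond the scatter) in this assay, which moves toward a weaker effect. This position is therefore the first in the series where a change is seen beyond the scatter, with compound 3 at 104% on this read-out. Nothing at hand bears on why the read-out moved.

Still open, as far as these compounds go, is whether a plain phenyl or a 4-chlorophenyl at this carbonyl carbon would read like compound 2 or like compound 3. Also open, from the compounds shown here alone, is whether loss of the amine or entry of the two chlorines carries the step.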